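The source may hold more compounds than are shown below. What is called first, only, known or untested is meant among the compounds shown, and "the series" means these compounds.

Compound 1 `CC(C)Cn1c(=O)n(C)c(=O)c2c1nc(Cc1cccc3ccccc13)c(=O)n2CCCCO` gives 548 nM in an assay on MCF7 cells for inhibition of Monocarboxylate transporter 1 (Homo sapiens), read by scintillation counting, with a stated time of 10 min; on this read-out higher numbers stand for weaker inhibition and lower numbers for stronger inhibition. Compound 2 `CC(C)Cn1c(=O)n(C)c(=O)c2nc([S+]([O-])CCCO)c(Cc3cccc4ccccc34)nc21` is recorded in this assay as "not determined" (no result reported), so where it stands on the numbers cannot be said. Compound 3 `CC(C)Cn1c(=O)n(C)c(=O)c2nc(CCCCCO)c(Cc3cccc4ccccc34)nc21` arises from compound 2 by a group of 6 heavy atoms (5 carbon, 1 oxygen; no ring) in place of a group of 6 heavy atoms (3 carbon, 2 oxygen, 1 sulfur; no ring), on an aromatic carbon. Among the compounds with values here, no measured step between compounds is available, so the size and direction of this change in this assay cannot be read from the data; it might lie within the scatter or move either way beyond it. Taking the value of compound 1 at 548 nM as the only anchor, compound 3 is expected near 600 nM, within a range from 120 nM to 3000 nM.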

Compound 3, half-maximal inhibitory concentration: 192 nM
Beside the measured number, compound 3's estimate is 3.1-fold (0.49 log units) above it; the measured number falls inside the stated range.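

No step can be read between compound 2 and compound 3. The compounds shown leave open how the 5-hydroxypentyl group of compound 3 compares in inhibition with the group in compound 2. No evidence at hand bears on this result.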